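The compounds below may be only part of what the source reports. "The series", "measured", "known", "first", "only" and "open" are said of these compounds alone.

Compound 1 `C/C(=C\C(=O)Nc1ccccc1OCCCC(=O)O)c1ccc2c(ccn2Cc2ccc(F)cc2)c1`: 97 nM
Compound 2 `CCCCC(c1ccccc1)n1ccc2cc(/C(C)=C/C(=O)Nc3ccccc3OCCCC(=O)O)ccc21`: 9.8 nM

Among the measured compounds shown here, in an assay on Prostate gland for inhibition of steroid 5-alpha-reductase (Rattus norvegicus) (a lower number here means a stronger inhibitor, a higher number a weaker inhibitor), compound 2 gives the lowest of the two numbers, and the single measured step, a 9.9-fold lower number from compound 1 to compound 2 (1.00 log units; beyond the scatter), concerns only the group on the aromatic nitrogen. Compound 3 `C/C(=C\C(=O)Nc1ccccc1OCCCC(=O)O)c1ccc2c(ccn2C(c2ccccc2)c2ccccn2)c1` differs from compound 2 by pyridin-2-yl in place of butyl on a saturated chain carbon bound to an aromatic carbon and an aromatic nitrogen. No measured step touches this position, so nothing shown speaks for a change beyond the scatter in either direction. Compound 3 is therefore expected to give about 15 nM, within 4 nM to 60 nM. This expectation amounts to a step of a 1.5-fold higher number from compound 2 to compound 3 (0.18 log units; within the scatter).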

Compound 3, half-maximal inhibitory concentration: 37 nM
Compound 3: the middle estimate sits 2.5-fold (0.39 log units) below what was measured; measured number inside the range.
By their numbers in this assay, from the lowest: compound 2; then compound 3; then compound 1.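

In this assay, the saturated chain carbon bound to an aromatic carbon and an aromatic nitrogen proves sensitive to its substituent: pyridin-2-yl in place of butyl gives a 3.8-fold higher number from compound 2 to compound 3 (0.58 log units; beyond the scatter) beyond the usual scatter. The earlier step concerned only the whole group on the aromatic nitrogen, whereas this one shows that butyl and pyridin-2-yl are not interchangeable at this carbon. No evidence is available to explain the difference. Going by these compounds, whether a second phenyl, a propyl chain or an amine at this carbon would stay closer to compound 2 remains open. Also open, on these data alone, is whether the ring nitrogen of pyridin-2-yl or the ring as a whole accounts for the step.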